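The source may report more compounds than this note shows. Statements on the series, on what has been measured and on what is new or still open speak of the compounds shown alone.

Of the compounds shown here, three sharing one core have been measured in a functional assay on the whole organism for inhibition, with Rattus norvegicus as the target, read by paw edema, at a dose of 100 mg/kg by the oral route; on this read-out higher numbers stand for more inhibition at the one dose given (going by the name of the read-out) and lower numbers for less inhibition. Compound 1 `CCCCNC(=O)c1c(O)c2cccnc2n(-c2ccccc2)c1=O` gives 12.8%. Compound 2 `O=C(NN1CCOCC1)c1c(O)c2cccnc2n(-c2ccccc2)c1=O` gives -8.5%. Compound 3 `COc1ccccc1NC(=O)c1c(O)c2cccnc2n(-c2ccccc2)c1=O` gives 8.1%, the second highest of the three numbers: its gap to compound 1 lies within the scatter, while a number 16.6 percentage points higher from compound 2 to compound 3 (beyond the scatter) lies beyond it. Compound 4 `O=C(Nc1ccc(Cl)nc1)c1c(O)c2cccnc2n(-c2ccccc2)c1=O` differs from compound 3 in one place: 6-chloropyridin-3-yl in place of 2-methoxyphenyl on an amide-type nitrogen. The measured steps that bear on this change are the two that reach compound 3 from the other compounds, namely a number 4.7 percentage points lower from compound 1 to compound 3 (within the scatter) and a number 16.6 percentage points higher from compound 2 to compound 3 (beyond the scatter). Among the compounds with values here, both swap the group on the amide-type nitrogen, but neither replaces one aromatic group with another, so no measured step matches the present change closely. The available comparisons show at most modest movement, and the present swap keeps an aromatic ring in place. For compound 4 the expected step is therefore a number 0.1 percentage points lower from compound 3 to compound 4 (within the scatter), which stays within the scatter. Compound 4 is expected to give about 8%, with a range from -6% to 22%.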

Compound 4, a percentage reported as inhibition, in the whole organism at one dose (the size of the read-out at that dose, not a potency): 9.2%
Estimate against measurement, compound 4: 1.2 percentage points below; the range from low to high includes it.
By their numbers in this assay, from the lowest: compound 2; then compounds 3, 4 and 1 (each within the scatter of the next).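

With 6-chloropyridin-3-yl in place of 2-methoxyphenyl, one aromatic group on the amide-type nitrogen can now be compared directly with another, and in this assay the result is a number 1.1 percentage points higher from compound 3 to compound 4 (within the scatter), so these two groups cannot be told apart. Butyl cannot be told apart from the new group either, with a number 3.6 percentage points lower from compound 1 to compound 4 (within the scatter), whereas morpholin-4-yl can, with a number 17.7 percentage points higher from compound 2 to compound 4 (beyond the scatter) as the step. Among the four groups shown at this position, only morpholin-4-yl stands apart, with the lowest number, while the other three form a single group within the scatter.

Nothing given here explains these numbers. On these data alone, it remains open whether a longer chain than butyl, or a pyridine ring bearing an amine or a carboxylic acid in place of the chlorine, would rise clear of this group.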